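Changing one aryl group on a compound at the limit

The source may report more compounds than this note shows. Statements on the series, on what has been measured and on what is new or still open speak of the compounds shown alone.

In an ADME assay on HCT-116 cells (Homo sapiens) for cytotoxicity, read by CellTiter-Glo, with a stated time of 72 h (a higher number here means a weaker inhibitor, a lower number a stronger inhibitor), compound 1 `Cc1cc(C)c(S(=O)(=O)NCCN2CCC(C)CC2)c(C)c1` gives only a limit, > 5000 nM. Compound 3 `CCCC(=O)NC1CCN(S(=O)(=O)c2c(C)cc(C)cc2C)CC1` also gives only a limit, > 5000 nM. Compound 2 `COc1ccc(-c2cccc(S(=O)(=O)N3CCC(N4CCC(C)CC4)CC3)c2)cc1` gives a limit too, > 5000 nM. Compound 2 therefore sits with the others at the limit of > 5000 nM in this assay, at which 3 of the 3 values shown sit. Compound 4 `CC1CCN(C2CCN(S(=O)(=O)c3cccc(-c4ccccc4C(F)(F)F)c3)CC2)CC1` differs from compound 2 in one place: 2-(trifluoromethyl)phenyl in place of 4-methoxyphenyl on an aromatic carbon. In words, 2-(trifluoromethyl)phenyl stands in place of 4-methoxyphenyl on an aromatic carbon. Going by the values given here, no measured pair yet shows the effect of a single change in this assay. The expected change, a number no higher from compound 2 to compound 4 (the limit leaves the size open), is none beyond the usual scatter, and another limit is the likeliest report. For compound 4 the estimated value is 5000 nM, with an expected range from 2500 nM to 10000 nM.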

Compound 4, half-maximal inhibitory concentration: > 5000 nM
Compound 4: no number, only a limit (the forecaster's own chance of this, stated with the estimate: 80%); the middle value lies on the limit itself.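

No step can be read from compound 2 to compound 4, because both give only a limit and no number: the limit of > 5000 nM in this assay, at which 4 of the 4 values shown sit.

The compounds shown leave open whether 2-(trifluoromethyl)phenyl in place of 4-methoxyphenyl changes cytotoxicity at all.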